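This account rests on a few compounds, and the source may have more. Where it says the series, first, only, none or still open, it means among the compounds named here.

The measured compounds:
compound 1, `CCOC(=O)c1sc(-c2cccc(NC(=O)c3cccc(F)c3)c2)nc1Nc1ccc(N2CCN(C)CC2)cc1`, gives 85.2% in a functional assay on Ramos cells (Homo sapiens) for antiproliferative activity, read by CCK-8 assay, with a stated time of 72 h, tested at 40 uM; a lower number here means less inhibition, a higher number more inhibition at the concentration tested (going by the name of the read-out);
compound 2, `CCOC(=O)c1sc(-c2cccc(NC(=O)c3ccccc3F)c2)nc1Nc1ccc(N2CCN(C)CC2)cc1`, gives 96.4%;
compound 3, `CN1CCN(c2ccc(Nc3nc(-c4cccc(NC(=O)c5cccc(F)c5)c4)sc3C(N)=O)cc2)CC1`, gives 16.2%.

Compound 4, `CN1CCN(c2ccc(Nc3nc(-c4cccc(NC(=O)c5ccccc5F)c4)sc3C(N)=O)cc2)CC1`, has not yet been measured in this assay. It differs from compound 3 by 2-fluorophenyl in place of 3-fluorophenyl on a carbonyl carbon. The same change is made from compound 1 to compound 2, (2-fluorophenyl in place of 3-fluorophenyl on a carbonyl carbon), and that step in this assay is a number 11.2 percentage points higher from compound 1 to compound 2 (beyond the scatter). Both changes sit on a carbonyl carbon whose other neighbours are an amide-type nitrogen, so they are the same change, found in two pairs among the compounds shown. The cores of the two pairs differ in one place, (amino in place of ethoxy on a carbonyl carbon), a change that brings a number 69 percentage points lower from compound 1 to compound 3 (beyond the scatter) and leaves compound 3 with the lowest number of the three. Within the data shown here, from compound 3 to compound 4 a step of about a number 11.8 percentage points higher from compound 3 to compound 4 (beyond the scatter) is expected, in the same direction as the earlier one, because a number 11.2 percentage points higher from compound 1 to compound 2 (beyond the scatter) is the only measured step for this change; it rests on one pair alone, and the core of compound 3 starts far lower, so its size is uncertain. Compound 4 is therefore expected to give about 28%, within 12% to 48%.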

Compound 4, a percentage reported as inhibition, at one concentration (the size of the read-out at that concentration, not a potency): 95.5%
Beside the measured number, compound 4's estimate is 67.5 percentage points below it; the whole stated range lies below it.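

Changing 3-fluorophenyl to 2-fluorophenyl raises the number on both cores in this assay, but the size of the step does not carry from one core to the other: the same change on two cores in this assay, a number 11.2 percentage points higher (beyond the scatter) from compound 1 to compound 2 and a number 79.3 percentage points higher (beyond the scatter) from compound 3 to compound 4, 68.1 percentage points apart, beyond the scatter of two such steps. On the core carrying amino the change gives a number 79.3 percentage points higher from compound 3 to compound 4 (beyond the scatter), and with 2-fluorophenyl in place, swapping ethoxy for amino gives a number 0.9 percentage points lower from compound 2 to compound 4 (within the scatter), so the effect of each change depends on the group at the other place: the same change on two cores in this assay, a number 69 percentage points lower (beyond the scatter) from compound 1 to compound 3 and a number 0.9 percentage points lower (within the scatter) from compound 2 to compound 4, 68.1 percentage points apart, beyond the scatter of two such steps. These four compounds show only that dependence, at one concentration, and they do not show why it arises or whether it extends beyond this series.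

The compounds shown leave open whether the same dependence appears with other groups on that carbonyl carbon, such as an unsubstituted phenyl or a methoxyphenyl, or with a hydroxyl or a methylamino group in place of ethoxy or amino. Also open, going by these compounds, is how the four compounds compare at other concentrations.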